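The compounds below may be only part of what the source reports. "The series", "measured", "known", "first", "only" and "open" are said of these compounds alone.

Measured so far in a functional assay on HepG2 cells (Homo sapiens) for antiproliferative activity, with a stated time of 72 h; on this read-out lower numbers stand for an effect already at smaller amounts and higher numbers for an effect only at larger amounts of compound:

compound 1 `COc1ccc(-c2cc(=O)c3c(OC)cc(OC)cc3n2C)cc1` — "not determined" (no result reported)

compound 2 `C=CCNC(=O)n1c(-c2ccc(OC)cc2)cc(=O)c2c(OC)cc(OC)cc21` — > 20000 nM, a limit of this assay

compound 3 `COc1ccc(-c2cc(=O)c3c(OC)cc(OC)cc3n2S(=O)(=O)c2ccc(Cl)cc2)cc1` — > 34400 nM, a limit of this assay

Going by the values given here, compound 3 therefore has no number of its own in this assay; its entry is a limit, and the one other measured compound also sits at a limit. The step that the two limits leave unreadable from compound 2 to compound 3 cannot be read for size. Compound 4 `COc1ccc(-c2cc(=O)c3c(OC)cc(OC)cc3n2S(=O)(=O)c2ccc(C)cc2)cc1` differs from compound 3 by methyl in place of chloro on an aromatic carbon. Among the compounds with values here, no measured step bears on this change; the two limits the limit of > 20000 nM in this assay, at which 1 of the 3 values shown sits, and the limit of > 34400 nM in this assay, at which 1 of the 3 values shown sits, only fix where compound 2 and compound 3 sit. Compound 4 is thus expected to stay near compound 3, most likely again at a limit, with the step that the limit leaves unreadable from compound 3 to compound 4 an estimate with little support. For compound 4 the estimate is 35000 nM, within 8000 nM to 150000 nM.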

Compound 4, half-maximal effective concentration: > 44800 nM
Compound 4: only a limit was reported; the forecaster's own chance of this, stated with the estimate: 80%; middle value at least 1.2-fold (0.10 log units) from the limit.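

In this assay, going by these compounds alone, compound 2, compound 3 and compound 4 each stand only at a limit, so no step among them can be read. The compounds shown leave open what size of effect, if any, methyl in place of chloro has on antiproliferative activity.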